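Compound 1 to compound 4: hydroxy to methoxy

The compounds below may be only part of what the source reports. "The series", "measured", "known", "first", "only" and "open" are said of these compounds alone.

In a functional assay on SKW 6.4 cells (Homo sapiens) (on this read-out higher numbers stand for an effect only at larger amounts of compound and lower numbers for an effect already at smaller amounts), compound 1 `C/C=C/C1=C(CO)[C@H](O)[C@H]2O[C@H]2C1=O` gives > 80 uM, which is a limit and not a number. Compound 2 `C=CC1=C(CO)[C@H](O)[C@H]2O[C@H]2C1=O`, with vinyl in place of prop-1-en-1-yl, gives > 80 uM, also a limit. Compound 3 `C/C=C/C1=C(CO)[C@@H](O)[C@@H]2O[C@@H]2C1=O` gives > 80 uM, again a limit. All three measured compounds therefore stand at the same mark: the limit of > 80 uM in this assay, at which 3 of the 3 values shown sit. Neither measured step has a readable size: a step that the two limits leave unreadable from compound 1 to compound 2 is one, and a step that the two limits leave unreadable from compound 1 to compound 3 is the other. The second pair is set apart only by the fact that compounds 1 and 3 differ only in the configuration as drawn.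

Compound 4 `C/C=C/C1=C(CO)[C@H](OC)[C@H]2O[C@H]2C1=O` carries methyl in place of hydrogen on an oxygen on a saturated carbon, a change from hydroxy to methoxy: methyl in place of hydrogen on an oxygen on a saturated carbon. Neither measured step alters this hydroxy, so they bear on the change only indirectly. For the measured compounds named here, both the vinyl swap and the change of configuration left the read-out at the limit, and no measured compound offers a number to work from. No readable step is therefore expected in this assay, and compound 4 will most likely report only a limit as well. The expected step, a rough estimate, is a step that the limit leaves unreadable from compound 1 to compound 4. For compound 4 the estimated value is 100 uM, with an expected range from 40 uM to 200 uM.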

Compound 4, concentration for half-maximal effect: > 80 uM
Compound 4 gave a limit, no number; the forecaster's own chance of this, stated with the estimate: 85%; the middle value does not contradict the limit.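

In this assay compound 4 gives > 80 uM, a limit and not a number. Compound 1 also stands at a limit, so no step can be read between the two, and the series sits at one mark: the limit of > 80 uM in this assay, at which 4 of the 4 values shown sit. The compounds shown leave open whether the change from hydroxy to methoxy alters the read-out at all.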